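Phenyl-oxazole swap on the amide carbonyl

The source may report more compounds than this note shows. Statements on the series, on what has been measured and on what is new or still open speak of the compounds shown alone.

- Compound 1 `O=C(N[C@H]1CN(S(=O)(=O)c2ccccc2)C[C@@H]1C(=O)N[C@H]1CCCNC1)c1cc(C2CC2)n[nH]1` in a physicochemical assay for solubility, at pH 7.4 (a higher number here means a more soluble compound, a lower number a less soluble compound), gives 861000 nM
- Compound 2 `O=C(N[C@H]1CN(S(=O)(=O)c2ccccc2)C[C@@H]1C(=O)N[C@H]1CCCNC1)c1cn(C2CC2)cn1` gives 664000 nM

Compound 2 lies within the scatter of compound 1 in this assay so the pair has no order. Next comes compound 3 `O=C(N[C@H]1CN(S(=O)(=O)c2ccccc2)C[C@@H]1C(=O)N[C@H]1CCCNC1)c1cc(-c2ccccc2)on1` with the change 5-phenyl-1,2-oxazol-3-yl in place of 1-cyclopropyl-1H-imidazol-4-yl on a carbonyl carbon in which 5-phenyl-1,2-oxazol-3-yl stands in place of 1-cyclopropyl-1H-imidazol-4-yl on a carbonyl carbon. For the measured compounds named here, the only measured step at this place is a 1.3-fold lower number from compound 1 to compound 2 (0.11 log units; within the scatter) and it gives little guidance for this new group. The expected move is a 2.2-fold lower number from compound 2 to compound 3 (0.35 log units; beyond the scatter) as a cautious call toward a lower number. Compound 3 is estimated at 300000 nM with a range of 80000 nM to 750000 nM in this estimate.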

Compound 3, solubility: 94000 nM
Estimate against measurement, compound 3: 3.2-fold (0.50 log units) above; low and high end bracket the measured number.
By their numbers in this assay, from the lowest: compound 3; then compounds 2 and 1 (each within the scatter of the next).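

The position on the carbonyl carbon is not flat in this assay: the two cyclopropyl-bearing rings stayed within the scatter, whereas 5-phenyl-1,2-oxazol-3-yl gives a 7.1-fold lower number from compound 2 to compound 3 (0.85 log units; beyond the scatter) and a 9.2-fold lower number from compound 1 to compound 3 (0.96 log units; beyond the scatter) in the same series. For the compounds shown here, this is the first step at this place to exceed the scatter, and it holds against both earlier groups. No evidence on the origin of this step is available.

The step changes both the five-membered ring and its substituent, so 5-cyclopropyl-1,2-oxazol-3-yl would be needed to separate the two. Also open, going by these compounds, is how an amine or carboxylic acid on the phenyl ring would read here.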